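Chain length and growth inhibition in three nucleoside analogues

The source may report more compounds than this note shows. Statements on the series, on what has been measured and on what is new or still open speak of the compounds shown alone.

Compound 1 `CCCCCCc1cn([C@H]2C[C@@H]3OP(=O)(O)OC[C@H]3O2)c(=O)[nH]c1=O`: in a functional assay on L1210 cells (Mus musculus) (a higher number here means a weaker inhibitor, a lower number a stronger inhibitor), compound 1 gives > 500 ug/mL, which is a limit of the assay rather than a number.
Compound 2 `CCCCc1cn([C@H]2C[C@H](O)[C@@H](CO)O2)c(=O)[nH]c1=O`: in this assay compound 2 gives > 500 ug/mL, again a limit.
Compound 3 `CCCCCc1cn([C@H]2C[C@@H]3OP(=O)(O)OC[C@H]3O2)c(=O)[nH]c1=O`: in this assay compound 3 gives > 500 ug/mL, also a limit.

Compound 3 and compound 1 share a core and differ in one place: methyl in place of hydrogen on a saturated chain carbon, five bonds along the chain from an aromatic carbon. The step that the two limits leave unreadable from compound 3 to compound 1 cannot be read as a size, because of the limit of > 500 ug/mL in this assay, at which 3 of the 3 values shown sit. Compound 2 carries a different core; how the two cores differ is not broken down here.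

Compound 4 `CCCCCc1cn([C@H]2C[C@H](O)[C@@H](CO)O2)c(=O)[nH]c1=O` has not yet been measured. It stands to compound 2 as compound 1 stands to compound 3: methyl in place of hydrogen on a saturated chain carbon, four bonds along the chain from an aromatic carbon. The place is not identical, since the new methyl sits four bonds along the chain from the aromatic carbon here and five bonds along in the pair of compound 3 and compound 1, so this is the same kind of change rather than the same change.

For compound 4 the expected step of a number no higher from compound 2 to compound 4 (the limit leaves the size open) in this assay is set beside the unreadable a step that the two limits leave unreadable from compound 3 to compound 1 and rests on compound 2 giving > 500 ug/mL and on all three measured compounds sitting at the same limit. Compound 4 is estimated at 500 ug/mL, with a range from 250 ug/mL to 1000 ug/mL, and most likely only a limit will be reported.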

Compound 4, concentration for 50% inhibition: 476 ug/mL
For compound 4 the middle estimate is 1.1-fold (0.02 log units) above the measured one, and the stated range covers the measured number.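

On the core of compound 2, adding the methyl gives an at least 1.0-fold lower number from compound 2 to compound 4 (0.02 log units; that floor lies within the scatter) in this assay, and this floor is the only size that can be read for the change in this series. From the compounds shown here alone, compound 2 itself sits at a limit of the assay rather than at a number, > 500 ug/mL, so the true size of the step stays open, and the data show neither a real effect of the methyl nor the absence of one. Whether the change carries from one core to the other is not shown, as the matching step from compound 3 to compound 1, with the methyl five bonds along the chain rather than four, cannot be read, and the two steps cannot be set side by side because most of the values are limits: the limit of > 500 ug/mL in this assay, at which 3 of the 4 values shown sit.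

The compounds shown leave open whether a longer chain on either core would bring the numbers clear of the limit and so give steps that can be compared across the two cores. Also open, going by these compounds, is how an amine or a carboxylic acid in place of the chain would read in this assay.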